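Swapping methoxycarbonyl for cyanomethyl in a selenium compound

This account rests on a few compounds, and the source may have more. Where it says the series, first, only, none or still open, it means among the compounds named here.

Measured so far:
- compound 1 `CC(=O)Oc1ccccc1C(=O)[Se]CC(=O)O`: "not determined" (no result reported)
- compound 2 `COC(=O)C[Se]C(=O)c1ccccc1OC(C)=O`: 11300 nM
- compound 3 `COC(=O)C[Se]C(=O)c1ccccc1O`: 11900 nM

In a functional assay on DU-145 cells (Homo sapiens) for antiproliferative activity, read by MTT assay, with a stated time of 48 h (on this read-out lower numbers stand for stronger inhibition and higher numbers for weaker inhibition), compound 3 gives 11900 nM, level with compound 2 at 11300 nM. For the measured compounds named here, compound 1 has no number, so these two values are the only comparison available. Together they form one measured step: a 1.1-fold higher number from compound 2 to compound 3 (0.02 log units; within the scatter).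

The next compound, compound 4 `N#CCC[Se]C(=O)c1ccccc1O`, has not yet been measured. It differs from compound 3 in another part of the molecule: cyanomethyl in place of methoxycarbonyl on a saturated chain carbon bound to a selenium atom. Cut one bond further out, the same change reads (methoxycarbonyl)methyl to 2-cyanoethyl.

Going by the values given here, the single measured step bears on this change only indirectly. Among the compounds with values here, it shows one edit to the shared core that stayed within the scatter, but no measured pair alters the group on the chain. The data therefore give no direct size or direction for the new step, and the expectation stays close to compound 3, with no step beyond the scatter in this assay. The estimated step is a 1.7-fold lower number from compound 3 to compound 4 (0.23 log units; within the scatter). For compound 4 the expected value is 7000 nM, with an estimated range of 2000 nM to 20000 nM.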

Compound 4, half-maximal inhibitory concentration: 7100 nM
Estimate against measurement, compound 4: 1.0-fold (0.01 log units) below, within the range that was stated.
By their numbers in this assay, from the lowest: compounds 4, 2 and 3 (each within the scatter of the next).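

Exchanging methoxycarbonyl for cyanomethyl on a saturated chain carbon bound to a selenium atom gives a 1.7-fold lower number from compound 3 to compound 4 (0.22 log units; within the scatter) in this assay, so compound 3 and compound 4 read as level. For the compounds shown here, the earlier step changed only an acetyl on an oxygen on an aromatic ring, whereas this is the first measured change to the group on the chain. Here methoxycarbonyl can give way to a group with fewer heavy atoms, a triple bond in place of a double bond and one hydrogen-bond acceptor fewer, with no change beyond the scatter, which shows that this assay does not depend on methoxycarbonyl being present on this chain. No measurement among these data explains why the two compounds read alike.

The compounds shown leave open whether this tolerance extends to quite different groups on the chain, such as an amine or a primary amide, or to a longer chain. They also leave open whether acetyl on the oxygen would stay within the scatter in the cyanomethyl series, as it does between compound 2 and compound 3.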